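A Methoxy-to-Oxolanyl Swap Tried on a Second Core

The compounds below may be only part of what the source reports. "The series", "measured", "known", "first", "only" and "open" are said of these compounds alone.

Compound 1 `CCC/C=C/C(=O)Nc1cc2c(N3CCc4ccccc43)ncnc2cc1OC` and compound 2 `CCC/C=C/C(=O)Nc1cc2c(N3CCc4ccccc43)ncnc2cc1O[C@@H]1CCOC1` share one core and differ only in that compound 2 carries oxolan-3-yl in place of methyl on an oxygen on an aromatic ring. In a functional assay on A549 cells (Homo sapiens) for antiproliferative activity, read by MTT assay, with a stated time of 72 h (a higher number here means a weaker inhibitor, a lower number a stronger inhibitor), compound 1 gives 2920 nM and compound 2 gives 9110 nM, a step of a 3.1-fold higher number from compound 1 to compound 2 (0.49 log units; beyond the scatter). Compound 3 `COc1cc2ncnc(N3CCCc4ccccc43)c2cc1NC(=O)/C=C/CN(C)C` is built on a different core; how that core differs from the core of compound 1 is not broken down here. In this assay compound 3 gives 1650 nM. Compound 4 `CN(C)C/C=C/C(=O)Nc1cc2c(N3CCCc4ccccc43)ncnc2cc1O[C@@H]1CCOC1` carries the same change on the core of compound 3: oxolan-3-yl in place of methyl on an oxygen on an aromatic ring. The place is the same in both pairs, so a similar loss is expected. For compound 4 the expected step is a 3.0-fold higher number from compound 3 to compound 4 (0.48 log units; beyond the scatter), because the first pair moved by a 3.1-fold higher number from compound 1 to compound 2 (0.49 log units; beyond the scatter). Compound 4 is thus estimated at 5000 nM, between 2500 nM and 10000 nM.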

Compound 4, half-maximal inhibitory concentration: 2320 nM
Compound 4: middle estimate off by 2.2-fold (0.33 log units), on the high side, and the stated range ends above it.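

On the second core in this assay, putting oxolan-3-yl in place of methyl gives a 1.4-fold higher number from compound 3 to compound 4 (0.15 log units; within the scatter), so here the swap leaves no change that stands clear of ordinary assay noise. Set beside the first pair, the two steps cannot be told apart: the same change on two cores in this assay, a 3.1-fold higher number (0.49 log units; beyond the scatter) from compound 1 to compound 2 and a 1.4-fold higher number (0.15 log units; within the scatter) from compound 3 to compound 4, 2.2-fold (0.35 log units) apart, within the scatter of two such steps. This does not show that the core alters the effect of the swap, nor that the loss seen on the first core carries over in full, and two pairs settle neither reading.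

As far as these compounds go, how other groups on that oxygen, such as ethyl or oxan-4-yl, would behave on either core stays open. So does the effect of the opposite stereocentre in the oxolan-3-yl group.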